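This account rests on a few compounds, and the source may have more. Where it says the series, first, only, none or still open, it means among the compounds named here.

Measured so far:
compound 2 `O=C(NCCNS(=O)(=O)c1ccc(-c2ccccc2OCc2cccc(O)c2)s1)Nc1cc(Cl)cc(Cl)c1` — 2800 nM
compound 1 `COc1ccc(NC(=O)NCCNS(=O)(=O)c2ccc(-c3ccccc3Oc3ccc([N+](=O)[O-])cc3)s2)cc1` — > 50000 nM (limit)

Among the measured compounds shown here, in a functional assay on HL-60 cells (Homo sapiens) for inhibition, read by CCK-8 assay, with a stated time of 48 h (on this read-out higher numbers stand for weaker inhibition and lower numbers for stronger inhibition), compound 2 gives 2800 nM, the only actual number in the set. Compound 1 gives > 50000 nM, a limit of the assay rather than a number, as noted in the limit of > 50000 nM in this assay, at which 1 of the 2 values shown sits.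

Compound 3 `COc1ccc(NC(=O)NCCNS(=O)(=O)c2ccc(-c3ccccc3OCc3cccc(O)c3)s2)cc1` remains to be measured in this assay. It differs from compound 2 by 4-methoxyphenyl in place of 3,5-dichlorophenyl on an amide-type nitrogen. For the measured compounds named here, no measured step of this kind exists here, so the size is uncertain; a loss of potency beyond the usual scatter is expected, since the 3,5-dichlorophenyl group leaves. Compound 3 is expected near 9000 nM, with a range from 2500 nM to 35000 nM. That estimate means an expected step of a 3.2-fold higher number from compound 2 to compound 3 (0.51 log units; beyond the scatter).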

Compound 3, half-maximal inhibitory concentration: > 20000 nM
Compound 3 was reported as a limit (the forecaster's own chance of this, stated with the estimate: 20%); middle value at least 2.2-fold (0.34 log units) away from the limit.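

In this assay compound 3 gives > 20000 nM, a limit of the assay and not a number. Among the compounds shown here, with 3-hydroxybenzyl on the oxygen held fixed, 4-methoxyphenyl in place of 3,5-dichlorophenyl on the amide-type nitrogen gives an at least 7.1-fold higher number from compound 2 to compound 3 (0.85 log units; beyond the scatter), the first readable step at this position. The step between compound 1 and compound 3 cannot be read, as both values are limits.

As far as these compounds go, how a plain phenyl or a 3-chlorophenyl on this nitrogen would read remains open. Also open, from the compounds shown here alone, is how far potency would return with either group, since the size of the loss is known only as a lower bound.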